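This account rests on a few compounds, and the source may have more. Where it says the series, first, only, none or still open, it means among the compounds named here.

Compound 3 `O=C(Nc1cccc(CNc2nccnc2Cl)c1)Nc1ccc(Cl)cc1Br` gives 6720 nM in a functional assay on HepG2 cells (Homo sapiens) for antiproliferative activity, read by MTT assay, with a stated time of 48 h (on this read-out lower numbers stand for stronger inhibition and higher numbers for weaker inhibition), the lowest of the two numbers shown. Compound 1 `Cc1ccc(NC(=O)Nc2cccc(CNc3nccnc3Cl)c2)cc1` gives 11500 nM in this assay, and the step of a 1.7-fold lower number from compound 1 to compound 3 (0.23 log units; within the scatter) stays within the scatter. Compound 2 `O=C(Nc1cccc(CNc2nccnc2Cl)c1)NC1CCCCC1` reaches only the limit > 40000 nM in this assay. Compound 4 `O=C(Nc1cccc(CNc2nccnc2Cl)c1)Nc1ccc(Cl)c(Cl)c1` differs from compound 3 by 3,4-dichlorophenyl in place of 2-bromo-4-chlorophenyl on an amide-type nitrogen. For the measured compounds named here, the one measured step that bears on such a swap of one aryl group for another is a 1.7-fold lower number from compound 1 to compound 3 (0.23 log units; within the scatter), which stayed within the scatter; the steps of an at least 3.4-fold higher number from compound 1 to compound 2 (0.54 log units; beyond the scatter) and an at least 5.9-fold lower number from compound 2 to compound 3 (0.77 log units; beyond the scatter) set cyclohexyl against an aryl group and are less telling here. A step of a 1.1-fold lower number from compound 3 to compound 4 (0.05 log units; within the scatter) is therefore expected, nothing beyond the scatter. Compound 4 is estimated at 6000 nM, with a range from 2500 nM to 15000 nM.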

Compound 4, half-maximal inhibitory concentration: 6170 nM
For compound 4 the middle estimate is 1.0-fold (0.01 log units) below the measured one; the measured number falls inside the stated range.
By their numbers in this assay, from the lowest: compounds 4, 3 and 1 (each within the scatter of the next). At a limit, above all of these: compound 2.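

Exchanging 2-bromo-4-chlorophenyl for 3,4-dichlorophenyl on the amide-type nitrogen moves a halogen pair without a reading beyond the scatter (a 1.1-fold lower number from compound 3 to compound 4 (0.04 log units; within the scatter)). The comparison with 4-methylphenyl also stays within the scatter (a 1.9-fold lower number from compound 1 to compound 4 (0.27 log units; within the scatter)), so these three aryl groups cannot be told apart here. Cyclohexyl remains clearly separate from 3,4-dichlorophenyl (an at least 6.4-fold lower number from compound 2 to compound 4 (0.81 log units; beyond the scatter)), though that step rests on a limit rather than a number: the limit of > 40000 nM in this assay, at which 1 of the 4 values shown sits.

The compounds shown leave open whether a pyridine ring, a benzyl group or a phenyl ring carrying a carboxylic acid or an amine on this nitrogen would hold the same level. They also leave open whether any aryl group can move the number beyond the scatter.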